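The compounds below may be only part of what the source reports. "The series", "measured", "known", "first", "only" and "open" are said of these compounds alone.

Working notes on the series. Compound 1 `O=C(Nc1cccc(-n2cc(-c3ccncc3)c(-c3cc(O)cc(Cl)c3)n2)c1)Nc1ccc(Cl)c(Cl)c1` in a functional assay on HCC 2998 cells (Homo sapiens) for inhibition, read by sulforhodamine B assay, with a stated time of 48 h, tested at 0.1 uM (a lower number here means a stronger effect, a higher number a weaker effect of the compound at the concentration tested), gives 110%. Compound 2 `COc1cc(Cl)cc(-c2nn(-c3cccc(NC(=O)Nc4cc(C(F)(F)F)cc(C(F)(F)F)c4)c3)cc2-c2ccncc2)c1` gives 105%. Compound 3 `COc1cc(Cl)cc(-c2nn(-c3cccc(NC(=O)Nc4ccc(Cl)c(Cl)c4)c3)cc2-c2ccncc2)c1` gives 96%, the lowest of the three numbers; its gap to compound 2 lies within the usual scatter, so no order between those two is claimed, while its gap to compound 1 lies beyond it. Among the measured compounds shown here, the only step between measured compounds that differ in one place is a number 14 percentage points lower from compound 1 to compound 3 (beyond the scatter), a methyl in place of hydrogen on an oxygen on an aromatic ring. Compound 4 `COc1cc(Cl)cc(-c2nn(-c3cccc(NC(=O)c4cccc(C(F)(F)F)c4)c3)cc2-c2ccncc2)c1` differs from compound 3 at another site: 3-(trifluoromethyl)phenyl in place of (3,4-dichlorophenyl)amino on a carbonyl carbon. For the measured compounds named here, no measured pair carries this change, so the methyl step does not bear on it, and the three measured compounds give no indication of whether the read-out moves at all. In the absence of any bearing step the expected change from compound 3 to compound 4 is a number 2 percentage points higher from compound 3 to compound 4 (within the scatter), none beyond the scatter. Compound 4 is estimated at 98%, within 84% to 112%.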

Compound 4, a percentage reported as activity, at one concentration (the size of the read-out at that concentration, not a potency): 104%
Compound 4: the middle estimate sits 6 percentage points below what was measured, and the stated range covers the measured number.
By their numbers in this assay, from the lowest: compounds 3, 4, 2 and 1 (each within the scatter of the next, the first and the last beyond it).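

Replacing (3,4-dichlorophenyl)amino with 3-(trifluoromethyl)phenyl on the carbonyl carbon gives a number 8 percentage points higher from compound 3 to compound 4 (within the scatter) in this assay, so this site now has a first reading, and it shows no change that can be told from the scatter. The exchange removes the hydrogen-bond donor of the (3,4-dichlorophenyl)amino group and alters the aromatic substituents, yet at the single concentration tested the read-out does not separate the two compounds. Nothing available explains why the read-out holds here.

As far as these compounds go, it remains open whether a group of another kind on this carbonyl carbon, such as a piperazine amine or a carboxylic acid, would move the read-out beyond the scatter. Also open, from the compounds shown here alone, is whether compound 3 and compound 4 would separate at other concentrations, since one concentration gives no potency.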